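The source may report more compounds than this note shows. Statements on the series, on what has been measured and on what is new or still open speak of the compounds shown alone.

Compound 2 `Cc1ccc(-c2cn(Cc3ccccc3)nn2)cc1` gives in a functional assay on KB cells (Homo sapiens) for antiproliferative activity, read by MTT assay, with a stated time of 72 h (a higher number here means a weaker inhibitor, a lower number a stronger inhibitor), a value of 79500 nM. Of the two numbers shown, compound 2 sits beside compound 1 `COc1ccc(-c2cn(Cc3ccccc3)nn2)cc1`, which in this assay gives 86600 nM; the two values lie within the scatter of each other, as the step of a 1.1-fold lower number from compound 1 to compound 2 (0.04 log units; within the scatter) shows. Compound 3 `FC(F)(F)c1ccc(-c2cn(Cc3ccccc3)nn2)cc1` differs from compound 2 by trifluoromethyl in place of methyl on an aromatic carbon. Within the data shown here, the only measured step touches the same aromatic carbon and stayed within the scatter, so no change beyond the scatter is expected for a 1.1-fold lower number from compound 2 to compound 3 (0.06 log units; within the scatter). Compound 3 is therefore estimated at 70000 nM, with a range from 25000 nM to 200000 nM.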

Compound 3, half-maximal inhibitory concentration: 60200 nM
The estimate for compound 3 lay 1.2-fold (0.07 log units) above the measured number, and the stated range covers the measured number.
By their numbers in this assay, from the lowest: compounds 3, 2 and 1 (each within the scatter of the next).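

At this aromatic carbon, trifluoromethyl now stands with methyl and methoxy without separating from either in this assay (the record gives a 1.3-fold lower number from compound 2 to compound 3 (0.12 log units; within the scatter) and a 1.4-fold lower number from compound 1 to compound 3 (0.16 log units; within the scatter)). Going from 1 heavy atom in methyl to 4 in trifluoromethyl thus left the number within the scatter, so all three groups remain indistinguishable here. Nothing available explains this result. Going by these compounds, whether an amine, a carboxylic acid or a longer chain on this carbon would move the number beyond the scatter remains open. So does whether these three groups would also match on another carbon of that ring.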